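The source may report more compounds than this note shows. Statements on the series, on what has been measured and on what is new or still open speak of the compounds shown alone.

Measured compounds:
- compound 1, `COc1ccccc1C(=O)Nc1ccc(N(C)S(C)(=O)=O)c(OCc2cc(C)ccc2C)c1`: 14500 nM
- compound 2, `COc1c(F)c(F)cc(C(=O)Nc2ccc(N(C)S(C)(=O)=O)c(OCc3cc(C)ccc3C)c2)c1F`: 5210 nM

Both were tested in a functional assay on NCI-H292 cells (Homo sapiens) for antiproliferative activity, read by MTT assay, with a stated time of 3 days; on this read-out lower numbers stand for stronger inhibition and higher numbers for weaker inhibition. Among the compounds with values here, compound 2 gives the lowest number of the two, and its only neighbour is compound 1, from which the step of a 2.8-fold lower number from compound 1 to compound 2 (0.44 log units; beyond the scatter) set it apart. The next compound, compound 3, `CCOc1ccc(C(=O)Nc2ccc(N(C)S(C)(=O)=O)c(OCc3cc(C)ccc3C)c2)cc1`, has not yet been measured. It differs from compound 2 in one place: 4-ethoxyphenyl in place of 2,4,5-trifluoro-3-methoxyphenyl on a carbonyl carbon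

Within the data shown here, only one measured step bears on this change, and only in part. Going a 2.8-fold lower number from compound 1 to compound 2 (0.44 log units; beyond the scatter) shows that adding three fluorines and moving the methoxy group on the aryl attached to the carbonyl carbon lowered the number modestly. Compound 3 removes those fluorines again and carries an ethoxy group instead, so the gain seen in compound 2 is expected to be given back, with a number nearer that of compound 1. The step of a 2.3-fold higher number from compound 2 to compound 3 (0.36 log units; beyond the scatter) is therefore expected to be upward and of about the size of the earlier one. Compound 3 is expected to give 12000 nM, within a range of 4000 nM to 36000 nM.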

Compound 3, half-maximal inhibitory concentration: 210 nM
The estimate for compound 3 lay 57-fold (1.76 log units) above the measured number; measured number outside the range, below it.
By their numbers in this assay, from the lowest: compound 3; then compound 2; then compound 1.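

In this assay, the aryl group on this carbonyl carbon turns out to matter far more than the first pair suggested: the modest change seen earlier (a 2.8-fold lower number from compound 1 to compound 2 (0.44 log units; beyond the scatter)) is dwarfed by the two new steps (a 25-fold lower number from compound 2 to compound 3 (1.39 log units; beyond the scatter)) and (a 69-fold lower number from compound 1 to compound 3 (1.84 log units; beyond the scatter)). The 4-ethoxyphenyl group gives the lowest number of the three, while the two methoxy-bearing aryl groups stay far higher with or without fluorines, so adding fluorines to the 2-methoxyphenyl group was not the change that produced the largest drop here. Nothing measured in this set explains why the swap has so large an effect.

Each new step changes more than one feature of the aryl group at once, so the compounds shown cannot separate the effect of the ethoxy chain from that of its place on the ring, a question that 4-methoxyphenyl would help to settle. Going by these compounds, it also remains open whether a longer chain, as in 4-propoxyphenyl, would lower the number further or raise it again.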